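Acyl chain length and growth inhibition in one ester series

The source may report more compounds than this note shows. Statements on the series, on what has been measured and on what is new or still open speak of the compounds shown alone.

Compound 1 `C=C[C@@](C)(/C=C/c1ccc(OC(C)=O)cc1)CCC=C(C)C`: 67%
Compound 2 `C=C[C@@](C)(/C=C/c1ccc(OC(=O)CC)cc1)CCC=C(C)C`: 54%
Compound 3 `C=C[C@@](C)(/C=C/c1ccc(OC(=O)CCCC)cc1)CCC=C(C)C`: 42%

In a functional assay on PC-3 cells (Homo sapiens) for inhibition, with a stated time of 48 h, tested at 50 uM (on this read-out lower numbers stand for less inhibition of growth and higher numbers for more inhibition of growth at the one concentration tested), compound 3 gives the lowest of the three numbers; compound 2 stands nearest and compound 1 furthest, both higher beyond the scatter. Compound 4 `C=C[C@@](C)(/C=C/c1ccc(OC(=O)CCCCCCCCC)cc1)CCC=C(C)C` differs from compound 3 by pentyl in place of hydrogen on a saturated chain carbon, four bonds along the chain from a carbonyl carbon. All three measured steps bear on this, since each lengthens the same chain on the ester: a number 13 percentage points lower from compound 1 to compound 2 (beyond the scatter), a number 12 percentage points lower from compound 2 to compound 3 (beyond the scatter) and a number 25 percentage points lower from compound 1 to compound 3 (beyond the scatter), each modest and each downward. A further lengthening is therefore expected to lower the number in this assay again, though the added chain is longer than in any measured step, so the size is uncertain. For compound 4 the expected step is a number 17 percentage points lower from compound 3 to compound 4 (beyond the scatter). Compound 4 is thus estimated at 25%, within 8% to 42%.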

Compound 4, percent growth inhibition at one concentration: 50%
Compound 4: the middle estimate sits 25 percentage points below what was measured, outside the stated range (above it).
By their numbers in this assay, from the lowest: compounds 3, 4 and 2 (each within the scatter of the next, the first and the last beyond it); then compound 1.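

In this assay the downward run from compound 1 through compound 3 does not extend to the added pentyl: with a number 8 percentage points higher from compound 3 to compound 4 (within the scatter) and a number 4 percentage points lower from compound 2 to compound 4 (within the scatter) as its steps, compound 4 cannot be separated from either neighbour. With a number 17 percentage points lower from compound 1 to compound 4 (beyond the scatter) as the remaining step, only the gap to the acetate stays beyond the scatter, so lengthening here no longer tracks the read-out in a simple way. Nothing at hand explains this result.

Open, from the compounds shown here alone, is what a still longer chain, or a chain carrying an amine, would give. Also open, going by these compounds, is whether this picture at one concentration holds across a range of concentrations.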